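The compounds below may be only part of what the source reports. "The series", "measured", "known", "first", "only" and "open" are said of these compounds alone.

Three measured compounds share one core and differ in the chain attached to it. Compound 1 `NC1=NC2(CCSCC2)N(OCCCOc2ccc(Cl)c(Cl)c2)C(N)=N1` and compound 3 `NC1=NC2(CCSCC2)N(OCCCOc2cccc(Cl)c2Cl)C(N)=N1` were entered into an assay on isolated protein for inhibition of Dihydrofolate reductase (Homo sapiens), read by spectrophotometry, using NADPH, with stated times of 5 s and 6 min (a higher number here means a weaker inhibitor, a lower number a stronger inhibitor), but for neither of them was a number obtained: in this assay compound 1 gives "not determined" (no result reported), and in this assay compound 3 gives "not determined" (no result reported). For the measured compounds named here, compound 2 `NC1=NC2(CCOCC2)N(OCCCOc2ccc(F)cc2)C(N)=N1` therefore stands alone: in this assay compound 2 gives 46.6 nM, and this is the only numeric result in the set, so no comparison between measured compounds can be drawn from it and no measured pair differing in a single place exists.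

Compound 4 `Cc1ccc(OCCCON2C(N)=NC(N)=NC23CCOCC3)cc1` differs from compound 2 in one place: methyl in place of fluoro on an aromatic carbon. Nothing in the set shows how this exchange moves the number. The expectation therefore rests on the exchange itself, which swaps one heavy atom for another without touching the count of hydrogen-bond donors or acceptors or the charge. Such a swap is expected to produce a step from compound 2 to compound 4 of a 1.0-fold lower number from compound 2 to compound 4 (0.02 log units; within the scatter), that is, a step that stays within the usual scatter rather than a clear shift in either direction. On that basis compound 4 is estimated to give 45 nM in this assay, with a plausible range from 15 nM to 130 nM.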

Compound 4, half-maximal inhibitory concentration: 56.8 nM
Beside the measured number, compound 4's estimate is 1.3-fold (0.10 log units) below it, and the stated range covers the measured number.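

For the compounds shown here, this is the first step in the set that can be read between compounds differing in one place: in this assay, putting methyl in place of fluoro on the aromatic carbon para to a large group gives a 1.2-fold higher number from compound 2 to compound 4 (0.09 log units; within the scatter) as the outcome of the exchange. With the shared core and the rest of the chain unchanged, the two compounds cannot be told apart in this read-out, so at this one position 4-fluorophenyl and 4-methylphenyl serve equally well as far as the half-maximal inhibitory concentration can show. Nothing shown here speaks to what lies behind this likeness.

One pair at one position cannot say how far this likeness reaches: a trifluoromethyl, a methoxy, an amine or a carboxylic acid on the same aromatic carbon could read quite differently. On these data alone, it also stays open whether methyl and fluoro would still read alike with a longer chain in place of the present one.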